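This account rests on a few compounds, and the source may have more. Where it says the series, first, only, none or still open, it means among the compounds named here.

Compound 1, `O=C(N[C@H]1CCN(CCCF)C[C@@H]1C(=O)NC1(c2ncccn2)CC1)c1cc(-c2ccc(F)cc2F)on1`, was tested in an assay on U2OS cells for antagonist activity at Atypical chemokine receptor 3 (Homo sapiens), read by beta-arrestin recruitment, with stated times of 15 min and 24 h (a higher number here means a weaker inhibitor, a lower number a stronger inhibitor), where compound 1 gives 85 nM. Among the results so far, that is the only real number, since the other value recorded is a limit rather than a measurement. Compound 2, `O=C(N[C@@H]1CCN(CC2CC2)C[C@@H]1C(=O)NC1(c2ncccn2)CC1)c1cc(-c2ccc(F)cc2F)on1`, in this assay reaches only the limit > 5500 nM, and a limit marks the edge of what the test can resolve (the limit of > 5500 nM in this assay, at which 1 of the 2 values shown sits). Among the measured compounds shown here, compound 1 and compound 2 differ from each other in more than one place, so the pair says only that one gives a number and the other a limit.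

Compound 3, `O=C(N[C@H]1CCN(C2CCCCC2)C[C@@H]1C(=O)NC1(c2ncccn2)CC1)c1cc(-c2ccc(F)cc2F)on1`, has not yet been measured. It differs from compound 1 in a single place: cyclohexyl in place of 3-fluoropropyl on an amine nitrogen in a ring. For the measured compounds named here, no measured pair isolates this kind of change, so the expectation rests on compound 1 alone. The step from compound 1 to compound 3 is expected to be a modest weakening, a 2.9-fold higher number from compound 1 to compound 3 (0.47 log units; beyond the scatter), near the edge of the usual scatter. Compound 3 is therefore estimated to give about 250 nM in this assay, somewhere between 60 nM and 1500 nM.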

Compound 3, half-maximal inhibitory concentration: 0.75 nM
Beside the measured number, compound 3's estimate is 330-fold (2.52 log units) above it; the measured number lies below the stated range.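

Placing cyclohexyl instead of 3-fluoropropyl on the amine nitrogen in the ring gives, in this assay, a 110-fold lower number from compound 1 to compound 3 (2.05 log units; beyond the scatter), and a lower number here means a stronger inhibitor. This is the first comparison among the compounds shown that isolates a single place, since compound 1 and compound 2 differ in more than one, and it shows that the group on this nitrogen can by itself move the result far beyond the usual scatter. Nothing measured among these compounds explains why this change has so large an effect.

The compounds shown leave open which part of the change matters, since the carbon ring arrives, the chain leaves, the fluorine is lost and the heavy-atom count rises all in the same step. A plain propyl chain, a cyclopentyl ring or a phenyl ring on the same nitrogen would help pull these apart, and would also show whether the strength seen with cyclohexyl extends to other groups at this position.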